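Naphthyl replacement for the dimethylaminophenyl arylidene

The source may hold more compounds than are shown below. What is called first, only, known or untested is meant among the compounds shown, and "the series" means these compounds.

In a functional assay on MCF7 cells (Homo sapiens) for cytotoxicity, read by sulforhodamine B assay, with a stated time of 48 h (a lower number here means a stronger inhibitor, a higher number a weaker inhibitor), compound 3 `CC(=O)OC[C@H]1O[C@@H](n2cc(CN3C(=O)/C(=C\c4ccc(N(C)C)cc4)c4ccccc43)nn2)[C@H](OC(C)=O)[C@@H](OC(C)=O)[C@@H]1OC(C)=O` gives 29800 nM, the lowest of the two numbers in hand. Compound 2 `CC(=O)OC[C@H]1O[C@@H](n2cc(CN3C(=O)/C(=C\C=C\c4ccccc4)c4ccccc43)nn2)[C@H](OC(C)=O)[C@@H](OC(C)=O)[C@@H]1OC(C)=O` stands nearest with 34100 nM, and the step of a 1.1-fold lower number from compound 2 to compound 3 (0.06 log units; within the scatter) is within the scatter. Compound 1 `CC(=O)OC[C@H]1O[C@@H](n2cc(CN3C(=O)/C(=C\c4ccc(C)cc4)c4ccccc43)nn2)[C@H](OC(C)=O)[C@@H](OC(C)=O)[C@@H]1OC(C)=O` reaches only a limit, > 100000 nM, in this assay. The step of an at least 3.3-fold lower number from compound 1 to compound 3 (0.52 log units; beyond the scatter) is thus at least modest. Compound 4 `CC(=O)OC[C@H]1O[C@@H](n2cc(CN3C(=O)/C(=C\c4ccc5ccccc5c4)c4ccccc43)nn2)[C@H](OC(C)=O)[C@@H](OC(C)=O)[C@@H]1OC(C)=O` differs from compound 3 by naphthalen-2-yl in place of 4-(dimethylamino)phenyl on a double-bonded chain carbon bound to a double-bonded ring carbon. The group that enters carries no acceptor, so the relevant comparison is the step of an at least 3.3-fold lower number from compound 1 to compound 3 (0.52 log units; beyond the scatter) in reverse, with the limit of > 100000 nM in this assay, at which 1 of the 3 values shown sits, marking how far compound 1 sits. A weakening step is therefore expected for compound 4: a 2.0-fold higher number from compound 3 to compound 4 (0.30 log units; within the scatter). Compound 4 is expected to give 60000 nM, within 20000 nM to 150000 nM.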

Compound 4, half-maximal inhibitory concentration: 46500 nM
Beside the measured number, compound 4's estimate is 1.3-fold (0.11 log units) above it; measured number inside the range.
By their numbers in this assay, from the lowest: compounds 3, 2 and 4 (each within the scatter of the next). At a limit, above all of these: compound 1.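

In this assay, a group with no hydrogen-bond acceptor holds up at this place: a 1.6-fold higher number from compound 3 to compound 4 (0.19 log units; within the scatter), and a 1.4-fold higher number from compound 2 to compound 4 (0.13 log units; within the scatter), so naphthalen-2-yl, 4-(dimethylamino)phenyl and 2-phenylethenyl cannot be separated here. Only 4-methylphenyl stands apart from naphthalen-2-yl, with an at least 2.1-fold lower number from compound 1 to compound 4 (0.33 log units; beyond the scatter), so the acceptor of compound 3 is not required to clear compound 1. Compound 1 itself remains a limit of the assay: the limit of > 100000 nM in this assay, at which 1 of the 4 values shown sits.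

Open, as far as these compounds go, is whether a morpholine or a carboxylic acid in the same place would move the number beyond the scatter of compound 3.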